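Removing a chloro group from a nitro-bearing ring

The source may hold more compounds than are shown below. What is called first, only, known or untested is meant among the compounds shown, and "the series" means these compounds.

Of the compounds shown here, three sharing one core have been measured in an assay for inhibition of Tryptophan 2,3-dioxygenase (Homo sapiens), with stated times of 10 min and 60 min; a higher number here means a weaker inhibitor, a lower number a stronger inhibitor. Compound 1 `Oc1ccc(CNc2cc(C(F)(F)F)cc3[nH]ncc23)cc1` carries a hydroxyphenyl group on the chain carbon attached to the ring nitrogen and gives 2550 nM. Compound 3 `FC(F)(F)c1cc(NC[C@@H]2CCCCN2)c2cn[nH]c2c1` has a piperidin-2-yl group in that place and gives 8050 nM. For the measured compounds named here, the only step measured between two compounds that differ in a single place is a 3.2-fold higher number from compound 1 to compound 3 (0.50 log units; beyond the scatter). Compound 2 `O=[N+]([O-])c1cc(Cl)ccc1CNc1cc(C(F)(F)F)cc2[nH]ncc12` bears both a nitro group and a chloro group on its ring and gives 1700 nM, the lowest of the three numbers; it sits within the scatter of compound 1 and beyond the scatter of compound 3.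

Compound 4 `O=[N+]([O-])c1ccccc1CNc1cc(C(F)(F)F)cc2[nH]ncc12` differs from compound 2 only by hydrogen in place of chloro on an aromatic carbon. Going by the values given here, no measured step speaks to this change: the one step on record concerns the group on the chain carbon, not a substituent on the aromatic ring, so there is nothing to indicate a shift in either direction. The expectation is therefore a step of a 1.3-fold higher number from compound 2 to compound 4 (0.11 log units; within the scatter), that is, none beyond the scatter. Compound 4 is expected to give 2200 nM, with a range from 900 nM to 5500 nM.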

Compound 4, half-maximal inhibitory concentration: 2550 nM
Compound 4: the middle estimate sits 1.2-fold (0.06 log units) below what was measured; measured number inside the range.
By their numbers in this assay, from the lowest: compounds 2, 1 and 4 (each within the scatter of the next); then compound 3.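

Replacing the chloro group with hydrogen, at the ring position meta to a nitro group and para to a large group, gives a 1.5-fold higher number from compound 2 to compound 4 (0.18 log units; within the scatter) in this assay. For the compounds shown here, this is the first direct reading at this position, since the earlier step concerned only the group on the chain carbon, and it shows that the two compounds cannot be told apart in this assay. A chloro group at this position is therefore not required for a value in this range, at least on a ring that also carries the nitro group. Nothing available explains why the change has so little effect on the number.

Only chloro and hydrogen are shown at this position, so it remains open whether a larger or different group, such as a methyl, a methoxy or an amine, would shift the number beyond the scatter. As far as these compounds go, the part played by the nitro group is also open, including what would happen if a nitrile or a carboxylic acid stood in its place.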